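Pyrazolyl benzamides on a tetrahydroquinoline urea core

The source may hold more compounds than are shown below. What is called first, only, known or untested is meant among the compounds shown, and "the series" means these compounds.

Measured compounds:
- compound 1, `CNC(=O)N1CCCc2ccc(NC(=O)c3cccc(-c4cc[nH]n4)c3)cc21`: 27.3%
- compound 2, `CNC(=O)N1CCCc2ccc(NC(=O)c3ccc(-c4cc[nH]n4)cc3)cc21`: 92.5%

Two compounds have been run in a functional assay on MV4-11 cells (Homo sapiens) for antiproliferative activity, with a stated time of 6 days, tested at 1.56 uM; on this read-out higher numbers stand for a stronger effect at the one concentration tested and lower numbers for a weaker effect. Compound 1 gives 27.3%, the lower of the two numbers. Going by the values given here, compound 2 gives 92.5%, and the gap between the two lies well outside the usual scatter; no step is defined for this pair, so only the two numbers themselves are noted.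

The next compound in the series is compound 3, `CNC(=O)N1CCCc2ccc(NC(=O)c3cccc(-c4ccn(C)n4)c3)cc21`, which has not yet been measured in this assay. Relative to compound 1 the change is methyl in place of hydrogen on an aromatic nitrogen, on the aromatic nitrogen of the five-membered aromatic ring with two nitrogens; cut one bond further out, it reads 1H-pyrazol-3-yl to 1-methyl-1H-pyrazol-3-yl.

Among the compounds with values here, no measured pair shows this change, so there is nothing to anchor its size. With compound 1 already low in this assay, the step from compound 1 to compound 3 is expected to be small, most likely within the scatter or a modest drop, a number 7.3 percentage points lower from compound 1 to compound 3 (within the scatter). Compound 3 is therefore estimated at 20%, with a range from 5% to 45%.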

Compound 3, a percentage reported as inhibition, at one concentration (the size of the read-out at that concentration, not a potency): 70.5%
For compound 3 the middle estimate is 50.5 percentage points below the measured one; the measured number lies above the stated range.
By their numbers in this assay, from the lowest: compound 1; then compound 3; then compound 2.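

Going from 1H-pyrazol-3-yl to 1-methyl-1H-pyrazol-3-yl on the core of compound 1 gives, in this assay, a number 43.2 percentage points higher from compound 1 to compound 3 (beyond the scatter), the first single change in the series that can be read as a step. At this aromatic nitrogen, then, the hydrogen of compound 1 is not needed for the effect at the one concentration tested, and a methyl there is tolerated and goes with a much stronger read-out. Going by these compounds alone, the two earlier compounds could not show this, since they differ in where the ring with two nitrogens is attached and not in anything on that ring, and nothing measured so far speaks to what lies behind the step.

A single pair cannot separate a gain from the methyl itself from a gain from losing the hydrogen, and an ethyl or a 2-methoxyethyl group on the same nitrogen would bear on that question. From the compounds shown here alone, it also remains open whether the same change carries over to compound 2, which gives 92.5% with the hydrogen in place, or whether this step holds only for the attachment found in compound 1.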